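From isopropoxy to butoxy on compound 1

The compounds below may be only part of what the source reports. "The series", "measured", "known", "first", "only" and "open" are said of these compounds alone.

In a functional assay on HCT-116 cells (Homo sapiens) for cytotoxicity, read by MTT assay, with a stated time of 48 h, in the presence of a further agent that is not named here (on this read-out lower numbers stand for an effect already at smaller amounts and higher numbers for an effect only at larger amounts of compound), compound 1 `COc1ccc(-c2cc(NNC(=O)Nc3cc(Cl)nc(OC(C)C)c3)nc3c2cnn3C)cc1` gives 39800 nM. Compound 2 `COc1ccc(-c2cc(NNC(=O)Nc3cc(Br)nc(Br)c3)nc3c2cnn3C)cc1` gives 45200 nM, and compound 3 `Cc1nn(C)c2nc(NNC(=O)Nc3cc(Cl)nc(Cl)c3)cc(-c3ccccc3)c12` gives 80000 nM. Both of these values lie within the scatter of the value for compound 1, so compound 1 does not stand apart from the other two.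

Compound 4 `CCCCOc1cc(NC(=O)NNc2cc(-c3ccc(OC)cc3)c3cnn(C)c3n2)cc(Cl)n1` has not yet been measured. It differs from compound 1 in one place: butyl in place of isopropyl on an oxygen on an aromatic ring. This is butyl in place of isopropyl on an oxygen on an aromatic ring, or isopropoxy to butoxy.

Among the compounds with values here, one measured step bears on this change, though only indirectly: a 1.1-fold higher number from compound 1 to compound 2 (0.06 log units; within the scatter). That exchange removes the isopropoxy group altogether. Within the data shown here, no measured pair swaps one alkyl chain for another, so the evidence is thin. Even so, no step beyond the scatter is expected in this assay. The estimated step is a 1.0-fold higher number from compound 1 to compound 4 (0.00 log units; within the scatter). Compound 4 is expected at 40000 nM, with an estimated range of 18000 nM to 85000 nM.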

Compound 4, half-maximal effective concentration: 36500 nM
Beside the measured number, compound 4's estimate is 1.1-fold (0.04 log units) above it; low and high end bracket the measured number.
By their numbers in this assay, from the lowest: compounds 4, 1, 2 and 3 (each within the scatter of the next, the first and the last beyond it).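

In this assay butyl in place of isopropyl on an oxygen on an aromatic ring gives a 1.1-fold lower number from compound 1 to compound 4 (0.04 log units; within the scatter) and so leaves the number within the scatter. Unlike the earlier step, which replaced the whole 2-chloro-6-isopropoxypyridin-4-yl group, this pair exchanges one alkyl chain for another at this oxygen, and it shows that this position tolerates a move from isopropoxy to butoxy in this assay without a step beyond the scatter. Nothing measured here speaks to the cause of this result.

From the compounds shown here alone, whether a longer chain such as hexyl, or a chain ending in an amine or a carboxylic acid, would move the number beyond the scatter remains open. Equally open, going by these compounds, is whether the same exchange would behave alike on a core other than that of compound 1.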